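This account rests on a few compounds, and the source may have more. Where it says the series, first, only, none or still open, it means among the compounds named here.

Measured in a functional assay on Caco-2 cells (Homo sapiens) for inhibition, read by MTT assay, with a stated time of 48 h, tested at 10 uM; a higher number here means more inhibition of growth at the concentration tested, a lower number less inhibition of growth:
- compound 1 `Cc1oc2c([C@H]3CCN(C)C[C@H]3O)c(O)cc(O)c2c(=O)c1C(O)c1c(F)cccc1Cl`: 18%
- compound 2 `CCOc1ccc(Br)c(C(O)c2c(C)oc3c([C@H]4CCN(C)C[C@H]4O)c(O)cc(O)c3c2=O)c1`: 5%

For the measured compounds named here, compound 2, at 5%, stands lowest of the two numbers so far in this assay. Compound 3 `Cc1oc2c([C@H]3CCN(C)C[C@H]3O)c(O)cc(O)c2c(=O)c1C(O)c1cccc(Cl)c1Cl` has 2,3-dichlorophenyl in place of 2-bromo-5-ethoxyphenyl on a saturated chain carbon bound to an aromatic carbon and an oxygen on a saturated carbon. Going by the values given here, only one measured step bears on this change: a number 13 percentage points lower from compound 1 to compound 2 (beyond the scatter), which brought in that same 2-bromo-5-ethoxyphenyl. Going by these compounds, removing it is expected to win back most of that modest loss, though 2,3-dichlorophenyl itself is untested. The expected change is a number 11 percentage points higher from compound 2 to compound 3 (beyond the scatter), upward. The estimate for compound 3 is 16%, with an expected range of 4% to 30%.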

Compound 3, percent growth inhibition at one concentration: 3%
Estimate against measurement, compound 3: 13 percentage points above, outside the stated range (below it).
By their numbers in this assay, from the lowest: compounds 3 and 2 (each within the scatter of the next); then compound 1.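

In this assay the new group gives a number 2 percentage points lower from compound 2 to compound 3 (within the scatter) and so does not separate 2,3-dichlorophenyl from 2-bromo-5-ethoxyphenyl on this carbon. The change also gives a number 15 percentage points lower from compound 1 to compound 3 (beyond the scatter) and shows that removing 2-bromo-5-ethoxyphenyl does not by itself bring the number back up, leaving 2-chloro-6-fluorophenyl alone in standing apart among these three groups. No measurement here offers a reason for this. Still open, going by these compounds, is how a plain phenyl or an aminophenyl would behave at this place. A pyridine ring there is equally untested in these compounds.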